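Ester Homologue of a Thioether Side Chain in Rat

The source may hold more compounds than are shown below. What is called first, only, known or untested is meant among the compounds shown, and "the series" means these compounds.

Compound 1 `CC(=O)c1c(C)nc2c(OCc3ccccc3)cccn12`: 57%
Compound 2 `Cc1nc2c(OCc3ccccc3)cccn2c1C#N`: 25%
Compound 3 `CSCc1c(C)nc2c(OCc3ccccc3)cccn12`: 29%

In a functional assay on the whole organism with Rattus norvegicus as the target, with a stated time of 4 h, at a dose of 40 mg/kg by the intraperitoneal route (a lower number here means less inhibition, a higher number more inhibition at the dose given (going by the name of the read-out)), compound 3 stands second highest of the three numbers: its nearest neighbour is compound 2, within the scatter, and its furthest is compound 1, beyond it. Compound 4 `COC(=O)Cc1c(C)nc2c(OCc3ccccc3)cccn12` differs from compound 3 by methoxycarbonyl in place of methylsulfanyl on a saturated chain carbon bound to an aromatic carbon. Within the data shown here, two measured steps bear on this change. The step of a number 28 percentage points lower from compound 1 to compound 3 (beyond the scatter) shows that exchanging acetyl for the thioether side chain cost inhibition, while a number 4 percentage points higher from compound 2 to compound 3 (within the scatter) shows no meaningful difference between cyano and the same chain. Compound 4 brings a carbonyl back, but on the chain rather than as acetyl, so the account expects only a modest rise, a number 6 percentage points higher from compound 3 to compound 4 (within the scatter), likely within the scatter. Compound 4 is therefore estimated at 35%, with a range from 15% to 58%.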

Compound 4, a percentage reported as inhibition, in the whole organism at one dose (the size of the read-out at that dose, not a potency): 23%
Compound 4: middle estimate off by 12 percentage points, on the high side, and the stated range covers the measured number.
By their numbers in this assay, from the lowest: compounds 4, 2 and 3 (each within the scatter of the next); then compound 1.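

In this assay the methoxycarbonyl chain falls in with the thioether and the nitrile, at a number 6 percentage points lower from compound 3 to compound 4 (within the scatter) and at a number 2 percentage points lower from compound 2 to compound 4 (within the scatter), while acetyl stands apart, at a number 34 percentage points lower from compound 1 to compound 4 (beyond the scatter) as the step to the chain. A carbonyl on the saturated chain carbon therefore does not by itself give what compound 1 gives, and among these four compounds only compound 1 stands apart. Nothing measured here explains this difference.

On these data alone, whether a carboxylic acid or an amide in place of the methoxycarbonyl, or a longer chain, would come closer to compound 1 remains open. So does whether a propanoyl group on the aromatic carbon would hold the level of acetyl.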